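Adding a Nitro Group to a Phenyl Hydrazone

This account rests on a few compounds, and the source may have more. Where it says the series, first, only, none or still open, it means among the compounds named here.

Measured compounds:
- compound 1 `CCOC(=O)N1CCC(=NNC(=O)c2ccc(F)cc2)CC1` gives 74800 nM in a functional assay, read by spectrophotometry, with a stated time of 2 h; a higher number here means a weaker inhibitor, a lower number a stronger inhibitor
- compound 2 `CCOC(=O)N1CCC(=NNC(=O)c2ccc([N+](=O)[O-])cc2)CC1` gives 51700 nM in this assay
- compound 3 `O=C(NN=C1CC(c2ccccc2)NC(c2ccccc2)C1)c1ccccc1` gives 42000 nM in this assay

Compound 3 shows the lowest of the three numbers, yet its gaps to compound 2 and to compound 1 both lie within the usual scatter, so none of the three can be called stronger or weaker than another.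

Compound 4 `O=C(NN=C1CC(c2ccccc2)NC(c2ccccc2)C1)c1ccc([N+](=O)[O-])cc1` differs from compound 3 in one place: nitro in place of hydrogen on an aromatic carbon. Among the compounds with values here, only one measured step resembles this change. Between compound 1 and compound 2 a nitro group took the place of fluoro on the same kind of ring, and that gave a 1.4-fold lower number from compound 1 to compound 2 (0.16 log units; within the scatter). That step was small and within the scatter, and the core of compound 3 is different, so the evidence for a clear shift is thin.

The step of a 1.2-fold lower number from compound 3 to compound 4 (0.08 log units; within the scatter) is therefore expected to stay small, with a slight lean toward a lower number. Compound 4 is estimated to give 35000 nM in this assay, with a likely range from 14000 nM to 90000 nM.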

Compound 4, half-maximal inhibitory concentration: 88100 nM
Beside the measured number, compound 4's estimate is 2.5-fold (0.40 log units) below it; low and high end bracket the measured number.
By their numbers in this assay, from the lowest: compounds 3, 2, 1 and 4 (each within the scatter of the next, the first and the last beyond it).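

In this assay, within the data shown here, the change from phenyl to 4-nitrophenyl gives a 2.1-fold higher number from compound 3 to compound 4 (0.32 log units; beyond the scatter) and is the first step in this set to pass beyond the usual scatter, though only modestly. On this core, then, the ring carbon para to a large group is a place where a substitution can register, and here nitro goes with a weaker inhibitor, whereas the earlier nitro step of a 1.4-fold lower number from compound 1 to compound 2 (0.16 log units; within the scatter) stays within the scatter, replaced fluoro rather than hydrogen and sits on a different core, so the two steps form no single pattern. Nothing measured here explains this shift.

On these data alone, whether the shift belongs to nitro in particular stays open, since an amine or a carboxylic acid at the same place could point either way. Also open, as far as these compounds go, is how the unsubstituted phenyl behaves on the core of compound 1.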